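This account rests on a few compounds, and the source may have more. Where it says the series, first, only, none or still open, it means among the compounds named here.

Compound 2 (`Cc1ccc(S(=O)(=O)N2CCCCC2C)cc1C#Cc1cc(Cl)ccc1OCC(=O)O`) gives "not determined" (no result reported) in an ADME assay on a cell-free system (plasma, Homo sapiens) (a higher number here means a larger unbound share of the compound, a lower number a smaller unbound share), and so offers no starting number. Compound 4 (`Cc1ccc(S(C)(=O)=O)cc1C#Cc1cc(Cl)ccc1OCC(=O)O`) differs from it by methyl in place of 2-methylpiperidin-1-yl on a sulfonyl sulfur. Compound 1 (`CN(C)S(=O)(=O)c1cncc(C#Cc2cc(Cl)ccc2OCC(=O)O)c1`) gives 0.033 in this assay and compound 3 (`O=C(O)COc1ccc(Cl)cc1C#Cc1cccnc1`) gives 0.029 there. Among the measured compounds shown here, the one measured step, a 1.1-fold lower number from compound 1 to compound 3 (0.06 log units; within the scatter) (hydrogen in place of dimethylsulfamoyl on an aromatic carbon), is a different change at a different place and bears only loosely. For the measured compounds named here, it gives no ground for expecting a shift beyond the scatter, and no step from compound 2 can be sized. Compound 4 is expected at 0.025 with an estimated range from 0.01 to 0.06 in the working notes.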

Compound 4, unbound fraction: 0.017
Compound 4: middle estimate off by 1.5-fold (0.17 log units), on the high side, within the range that was stated.
By their numbers in this assay, from the lowest: compounds 4, 3 and 1 (each within the scatter of the next).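

Compound 2 offers no number to set against compound 4, so no new step can be read. The compounds shown leave open what methyl in place of 2-methylpiperidin-1-yl does to the unbound fraction. No evidence on hand bears on this result.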